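Trimming the Amide Nitrogen on a Shared Core

The source may hold more compounds than are shown below. What is called first, only, known or untested is meant among the compounds shown, and "the series" means these compounds.

Three compounds share one core and differ in the group on the outer aromatic ring. Compound 1 `CN(C)c1ccc(-c2cc(C(=O)N[C@H]3CCCNC3)c(NC(N)=O)s2)cc1` carries a dimethylamino group there, compound 3 `CN(C)C(=O)c1ccc(-c2cc(C(=O)N[C@H]3CCCNC3)c(NC(N)=O)s2)cc1` a dimethylcarbamoyl group, and compound 2 `CN1CCN(C(=O)c2cc(-c3ccccc3)sc2NC(N)=O)CC1` is a related variant for which no result was reported. In a functional assay on HT-29 cells (Homo sapiens) (on this read-out higher numbers stand for an effect only at larger amounts of compound and lower numbers for an effect already at smaller amounts), compound 1 gives 90 nM, while compound 3 gives 320 nM. In this assay compound 2 gives "not determined" (no result reported). Within the data shown here, compound 3 therefore stands as the higher of the two numbers that exist, the only step being a 3.6-fold higher number from compound 1 to compound 3 (0.55 log units; beyond the scatter), which is dimethylcarbamoyl in place of dimethylamino on an aromatic carbon.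

Compound 4 `NC(=O)Nc1sc(-c2ccc(C(N)=O)cc2)cc1C(=O)N[C@H]1CCCNC1` keeps the amide of compound 3 but is trimmed at its nitrogen: amino in place of dimethylamino on a carbonyl carbon. Among the measured compounds shown here, no measured step exchanges these two groups; the single step, a 3.6-fold higher number from compound 1 to compound 3 (0.55 log units; beyond the scatter), concerns a different exchange and only shows that changes at this part of the molecule can move the read-out by a modest amount. For the measured compounds named here, with no direct precedent, the safest expectation is no shift beyond the usual scatter, with a wide range on either side.

Compound 4 is therefore expected to give about 300 nM, between 100 nM and 1000 nM. For compound 4 the expected step is a 1.1-fold lower number from compound 3 to compound 4 (0.03 log units; within the scatter).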

Compound 4, half-maximal effective concentration: 3200 nM
Compound 4: middle estimate off by 11-fold (1.03 log units), on the low side; the whole stated range lies below it.
By their numbers in this assay, from the lowest: compound 1; then compound 3; then compound 4.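

The amide on the outer ring is not a neutral place to trim. In this assay, amino in place of dimethylamino on a carbonyl carbon gives a 10-fold higher number from compound 3 to compound 4 (1.00 log units; beyond the scatter) and lies beyond the scatter, so the methyl groups on that nitrogen clearly count for this read-out, even though the carbonyl stays in place. Among these compounds, measured against the dimethylamino group on the aromatic carbon, the carbamoyl group gives a 36-fold higher number from compound 1 to compound 4 (1.55 log units; beyond the scatter) and is the only large step in this small set, while the dimethylcarbamoyl group of compound 3 sits at a number between those of compound 1 and compound 4, and nothing in the data available here explains why the read-out moves in this way.

The compounds shown leave open whether a methylamino group on the same carbonyl carbon would read close to dimethylamino, close to amino or somewhere in the middle, which would show how much of the shift follows from each methyl group. Also open, on these data alone, is how a longer chain on that nitrogen, such as diethylamino, or a carboxylic acid in place of the whole carbamoyl group would read in this assay.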